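Removing the hydroxy from compound 1 on the shared core

This account rests on a few compounds, and the source may have more. Where it says the series, first, only, none or still open, it means among the compounds named here.

Compound 1 `O=C(CCCCCc1cccc(CO)c1)N1CCOC1=O` carries a hydroxymethyl group on its aromatic ring. In an assay on HEK293 cells for inhibition of N-acylethanolamine-hydrolyzing acid amidase (Rattus norvegicus), read by LC-MS, with a stated time of 30 min (on this read-out higher numbers stand for weaker inhibition and lower numbers for stronger inhibition), compound 1 gives > 20000 nM, which is a limit of the assay and not a number. Compound 2 `COc1ccc(CCCCCC(=O)N2CCOC2=O)cc1` likewise gives only a limit, > 20000 nM. Compound 3 `O=C(O)c1ccc(CCCCCC(=O)N2CCOC2=O)cc1` also gives only a limit, > 20000 nM. Going by the values given here, the one comparable change, a step that the two limits leave unreadable from compound 2 to compound 3, therefore cannot be sized, and the whole picture is summarised by the limit of > 20000 nM in this assay, at which 3 of the 3 values shown sit.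

Compound 4 `Cc1cccc(CCCCCC(=O)N2CCOC2=O)c1` differs from compound 1 by hydrogen in place of hydroxy on a saturated chain carbon bound to an aromatic carbon. Among the compounds with values here, no measured step bears readably on this change, so no direction can be taken from the data. The expectation for compound 4 is therefore 30000 nM, within 8000 nM to 150000 nM, most likely reported again as a limit. The step this estimate means is a step that the limit leaves unreadable from compound 1 to compound 4.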

Compound 4, half-maximal inhibitory concentration: 350 nM
Estimate against measurement, compound 4: 86-fold (1.93 log units) above; the measured number lies below the stated range.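

In this assay, hydroxymethyl to methyl gives an at least 57-fold lower number from compound 1 to compound 4 (1.75 log units; beyond the scatter), the only readable step among the compounds shown, since the earlier step between limits cannot be read. At this saturated chain carbon bound to an aromatic carbon, exchanging one hydroxy for hydrogen separates a limit from a measured value. Compound 4 is the only compound shown with such a value: the limit of > 20000 nM in this assay, at which 3 of the 4 values shown sit.

The compounds shown leave open whether an aminomethyl or ethyl group in place of the methyl would keep this measured inhibition. They also leave open whether a longer chain on the shared core would do so.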